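A side-chain swap at the assay limit

This account rests on a few compounds, and the source may have more. Where it says the series, first, only, none or still open, it means among the compounds named here.

Compound 1 (`COc1cccc(CNC(=O)c2ccc(Oc3ccc(C)cc3)cc2)c1`) gives > 1000 h as a limit
Compound 2 (`Cc1ccc(Oc2ccc(C(=O)N(C)Cc3ccncc3)cc2)cc1`) gives > 1000 h as a limit
Compound 3 (`COc1ccc(C(=O)NCc2ccncc2)cc1`) gives > 1000 h as a limit

In a physicochemical assay for pharmacokinetics, at pH 4 (a lower number here means that the compound disappears faster, a higher number that the compound lasts longer), compound 1 gives > 1000 h as a limit of the assay and not a number. Compound 4 (`Cc1ccc(Oc2ccc(C(=O)NCCCN(C)C)cc2)cc1`) carries 2-(dimethylamino)ethyl in place of 3-methoxyphenyl on a saturated chain carbon bound to an amide-type nitrogen. In this assay no step beyond the scatter is expected in either direction, because the limit of > 1000 h in this assay, at which 3 of the 3 values shown sit, covers all three measured structures. The expected change is a step that the limit leaves unreadable from compound 1 to compound 4 and would lie within the scatter. Compound 4 is expected at 1500 h with an estimated range from 800 h to 3000 h and will most likely be reported as a limit again.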

Compound 4, half-life: > 1000 h
Compound 4: no number, only a limit (the forecaster's own chance of this, stated with the estimate: 90%); the middle value lies beyond the limit too.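

No step can be read from compound 1 to compound 4, as both stand at the same limit: the limit of > 1000 h in this assay, at which 4 of the 4 values shown sit. The compounds shown leave open whether 2-(dimethylamino)ethyl in place of 3-methoxyphenyl changes the half-life at all.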